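This account rests on a few compounds, and the source may have more. Where it says the series, first, only, none or still open, it means among the compounds named here.

Measured compounds:
compound 1, `O=C(O)CCc1ccc(NCc2cccc(C(F)(F)F)c2)cc1`, 186 nM in a functional assay on 1321-N1 cells for agonist activity at Free fatty acid receptor 1 (Homo sapiens), read by calcium flux; a lower number here means that less compound is needed, a higher number that more compound is needed for the effect
compound 2, `Cc1ccc(-c2cccc(CNc3ccc(CCC(=O)O)cc3)c2)cc1`, 126 nM in this assay

Compound 2 stands beside compound 1 on these two numbers: the step of a 1.5-fold lower number from compound 1 to compound 2 (0.17 log units; within the scatter) is within the scatter, so the two are not separated. Compound 3, `COc1ccccc1-c1cccc(CNc2ccc(CCC(=O)O)cc2)c1`, differs from compound 2 by 2-methoxyphenyl in place of 4-methylphenyl on an aromatic carbon. Within the data shown here, no measured step touches this change; the only step known, a 1.5-fold lower number from compound 1 to compound 2 (0.17 log units; within the scatter), concerns a different exchange and was itself within the scatter. Compound 3 is therefore expected to stay close to compound 2, with no step beyond the scatter, that is a 1.2-fold higher number from compound 2 to compound 3 (0.08 log units; within the scatter). The estimate for compound 3 is 150 nM, in the range 60 nM to 400 nM.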

Compound 3, half-maximal effective concentration: 69.2 nM
Compound 3: the middle estimate sits 2.2-fold (0.34 log units) above what was measured, within the range that was stated.
By their numbers in this assay, from the lowest: compounds 3, 2 and 1 (each within the scatter of the next, the first and the last beyond it).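

At this aromatic carbon, the change from 4-methylphenyl to 2-methoxyphenyl gives (a 1.8-fold lower number from compound 2 to compound 3 (0.26 log units; within the scatter)) in this assay, so compound 3 is not separated from compound 2. Against trifluoromethyl, however, 2-methoxyphenyl gives the first step at this position beyond the scatter, though a modest one (a 2.7-fold lower number from compound 1 to compound 3 (0.43 log units; beyond the scatter)). Nothing available bears on what lies behind this step.

The compounds shown leave open how an unsubstituted phenyl or a 2-hydroxyphenyl would compare at this position. They also leave open whether an amine on this ring would fall within the same narrow range.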